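Cytotoxicity notes on the core series: toward compound 3

This account rests on a few compounds, and the source may have more. Where it says the series, first, only, none or still open, it means among the compounds named here.

Of the compounds shown here, two of this shared core have been measured for toxicity. In an ADME assay on HEp-2 cells (Homo sapiens) for cytotoxicity (on this read-out higher numbers stand for lower toxicity in this test and lower numbers for higher toxicity in this test), compound 1 `CC(C)CCn1c(Cn2c(=O)n(C(C)C)c3ccccc32)nc2cc(CNC3CC3)ccc21` gives 17200 nM, the lowest of the two numbers shown; compound 2 `COC(=O)c1cccc2c1nc(Cn1c(=O)n(C(C)C)c3ccccc31)n2CCC(C)C` gives 49200 nM, a gap beyond the usual scatter. Compound 3 `CCc1ccc2c(c1)nc(Cn1c(=O)n(C(C)C)c3ccccc31)n2CCC(C)C` has not yet been measured. Its change from compound 1 is methyl in place of cyclopropylamino on a saturated chain carbon bound to an aromatic carbon. Within the data shown here, no direct step of this kind has been measured, so the size of the step is open; a modest rise is expected, leaning on the higher number of compound 2 49200 nM. For compound 3 the expected step is a 1.5-fold higher number from compound 1 to compound 3 (0.18 log units; within the scatter), giving an estimate of 26000 nM with a range of 10000 nM to 65000 nM.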

Compound 3, half-maximal cytotoxic concentration: 18500 nM
Compound 3: middle estimate off by 1.4-fold (0.15 log units), on the high side; the range from low to high includes it.
By their numbers in this assay, from the lowest: compounds 1 and 3 (each within the scatter of the next); then compound 2.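

Placing methyl in place of cyclopropylamino on a saturated chain carbon bound to an aromatic carbon gives a 1.1-fold higher number from compound 1 to compound 3 (0.03 log units; within the scatter) in this assay. The (cyclopropylamino)methyl group can therefore give way to ethyl with no step beyond the scatter, so this read-out does not separate the two groups here. No measured evidence bears on why the two compounds read alike.

From the compounds shown here alone, whether a primary amine, a carboxylic acid or a longer chain at this place would also read alike remains open. So does whether a larger cyclic amine such as morpholine would.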